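Adding a Side Chain to Compound 1

This account rests on a few compounds, and the source may have more. Where it says the series, first, only, none or still open, it means among the compounds named here.

Compound 1, `COc1ccc2c(c1)cc(-c1cc(OC)c(OC)c(OC)c1)n2Cc1ccccc1`, offers no exact potency to start from. In a functional assay on PC-3 cells (Homo sapiens) for cytotoxicity, read by MTT assay, with a stated time of 24 h (a lower number here means a stronger inhibitor, a higher number a weaker inhibitor), compound 1 gives > 30000 nM, which is a limit of the assay and not a number. Compound 2, `COc1ccc2c(c1)c(Cc1ccccc1)c(-c1cc(OC)c(OC)c(OC)c1)n2Cc1ccccc1`, gives > 30000 nM, which is also a limit. Both measurements therefore share one ceiling: the limit of > 30000 nM in this assay, at which 2 of the 2 values shown sit. Going by the values given here, the only measured step, a step that the two limits leave unreadable from compound 1 to compound 2, has no readable size or direction.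

Compound 3, `COc1ccc2c(c1)cc(-c1cc(OC)c(OC)c(OC)c1)n2Cc1ccc(OC(C)CN(C)C)cc1`, keeps the core of compound 1 and carries a single change, 1-((dimethylamino)methyl)ethoxy in place of hydrogen on an aromatic carbon, para to a large group. This is not the benzyl change seen in compound 2, so the measured step offers little guidance. The estimate must start from compound 1 at > 30000 nM, again a limit. A modest shift toward stronger inhibition in this assay is expected, although compound 3 could also remain at a limit. The expected change is an at least 2.0-fold lower number from compound 1 to compound 3 (0.30 log units; that floor lies within the scatter). Compound 3 is estimated at 15000 nM, with an expected range from 4000 nM to 40000 nM.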

Compound 3, half-maximal inhibitory concentration: 13300 nM
For compound 3 the middle estimate is 1.1-fold (0.05 log units) above the measured one; measured number inside the range.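

Compound 3 gives the series its first readable step: placing 1-((dimethylamino)methyl)ethoxy on an aromatic carbon, para to a large group, produces an at least 2.2-fold lower number from compound 1 to compound 3 (0.35 log units; beyond the scatter). The earlier pair could not show that this position responds to any change, and now one substituent there brings an exact number within reach of this assay. That number stands apart from the ceiling that held the other two compounds: the limit of > 30000 nM in this assay, at which 2 of the 3 values shown sit.

In this assay, on these data alone, compound 1 gives > 30000 nM, which is a limit and not a number, so the true size of the step remains unknown and it may be larger than the printed floor. The compounds shown also leave open which part of the side chain matters, and a simple methoxy group at this place, a chain ending in a hydroxyl group instead of the dimethylamino end, or a longer unbranched chain carrying the same amine would each help to separate the contribution of the ether oxygen, the branch and the amine.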